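Chloro for Methyl on the Triazole Aryl Ring

The source may report more compounds than this note shows. Statements on the series, on what has been measured and on what is new or still open speak of the compounds shown alone.

The study concerns a shared core carrying a substituted aryl group on a triazole nitrogen. Compound 1 `N#CC1=C(N)Oc2c(c3nc4ccccc4nc3c3ccccc23)C12C(=O)N(Cc1cnnn1-c1ccc(F)cc1)c1ccccc12` bears a 4-fluorophenyl there; compound 2 `COc1ccc(-n2nncc2CN2C(=O)C3(C(C#N)=C(N)Oc4c3c3nc5ccccc5nc3c3ccccc43)c3ccccc32)cc1` a 4-methoxyphenyl; compound 3 `Cc1ccc(C)c(-n2nncc2CN2C(=O)C3(C(C#N)=C(N)Oc4c3c3nc5ccccc5nc3c3ccccc43)c3ccccc32)c1` a 2,5-dimethylphenyl. In an ADME assay on HUVEC cells (Homo sapiens) for antiproliferative activity, read by MTT assay, with a stated time of 48 h (a lower number here means a stronger inhibitor, a higher number a weaker inhibitor), compound 1 reached only the limit of the assay, > 50000 nM. Compound 2 likewise sits at a limit in this assay, > 50000 nM. Compound 3 too gives only a limit in this assay, > 50000 nM. So compound 3 stands at the ceiling of what this assay can report, and the same holds for both other compounds. The steps a step that the two limits leave unreadable from compound 1 to compound 2, a step that the two limits leave unreadable from compound 1 to compound 3 and a step that the two limits leave unreadable from compound 2 to compound 3 are therefore all unreadable, because of the limit of > 50000 nM in this assay, at which 3 of the 3 values shown sit.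

Compound 4 `Cc1ccc(Cl)cc1-n1nncc1CN1C(=O)C2(C(C#N)=C(N)Oc3c2c2nc4ccccc4nc2c2ccccc32)c2ccccc21` differs from compound 3 by chloro in place of methyl on an aromatic carbon. None of the three measured steps gives a readable size, and all bear on the aryl group at the same triazole nitrogen. With every neighbour at the limit, the step from compound 3 to compound 4 is expected to be a step that the limit leaves unreadable from compound 3 to compound 4, with no readable direction. Compound 4 is therefore expected to give 60000 nM in this assay, within 30000 nM to 200000 nM, and most likely to return only a limit again.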

Compound 4, half-maximal inhibitory concentration: > 50000 nM
Compound 4 gave a limit, no number (the forecaster's own chance of this, stated with the estimate: 85%); the middle value lies beyond the limit too.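

Compound 4 gives only a limit in this assay, > 50000 nM. Among the compounds shown here, no step to compound 4 from compound 1, compound 2 or compound 3 can be read, because all four compounds sit at the same limit: the limit of > 50000 nM in this assay, at which 4 of the 4 values shown sit. The compounds shown leave open whether any aryl group on this triazole nitrogen gives a measurable value in this assay.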